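Trading Methoxy for Methyl on the Shared Core

The compounds below may be only part of what the source reports. "The series", "measured", "known", "first", "only" and "open" are said of these compounds alone.

In an ADME assay on brain (Rattus norvegicus) for protein binding (a higher number here means a larger unbound share of the compound, a lower number a smaller unbound share), compound 1 `Cc1c(CF)nnc2sc(C(=O)NC3CN(c4ncc(C(F)(F)F)cn4)C3)c(N)c12` gives 0.085 and compound 2 `COc1nnc2sc(C(=O)NC3CN(c4ncc(C(F)(F)F)cn4)C3)c(N)c2c1C` gives 0.039, the lower of the two numbers. Compound 3 `Cc1nnc2sc(C(=O)NC3CN(c4ncc(C(F)(F)F)cn4)C3)c(N)c2c1C` carries methyl in place of methoxy on an aromatic carbon. Within the data shown here, one measured step bears on this: a 2.2-fold lower number from compound 1 to compound 2 (0.34 log units; beyond the scatter), with methoxy in place of fluoromethyl on an aromatic carbon. Compound 3 also lacks the methoxy, so a rise in this assay of similar or smaller size is expected. The estimated change is a 1.7-fold higher number from compound 2 to compound 3 (0.22 log units; within the scatter). For compound 3 the expected value is 0.065, with an estimated range of 0.035 to 0.12.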

Compound 3, unbound fraction: 0.41
Compound 3: the middle estimate sits 6.3-fold (0.80 log units) below what was measured, outside the stated range (above it).
By their numbers in this assay, from the lowest: compound 2; then compound 1; then compound 3.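

In this assay methyl in place of methoxy on this aromatic carbon gives an 11-fold higher number from compound 2 to compound 3 (1.02 log units; beyond the scatter) and hydrogen in place of fluoro on the saturated chain carbon bound to it gives a 4.8-fold higher number from compound 1 to compound 3 (0.68 log units; beyond the scatter) as well. The earlier step showed only a modest gap between fluoromethyl and methoxy, whereas both now sit well under plain methyl, and this place proves far more responsive than that step suggested. Nothing measured here accounts for the size of these steps. The compounds shown leave open how ethyl, chloro or an amine would read at this carbon.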